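Methyl for Hydroxyl on the Sulfonyl Arene of Compound 2

A few compounds are considered here, and "the series" means these few. Any claim that something is new, unique, unknown or untested is made for them only; others in the source may bear on it.

Compound 2 `O=S(=O)(Nc1ccc2oc(-c3ccccc3)nc2c1)c1ccccc1O` is one of three sulfonamides measured in an ADME assay on HEK293 cells (Homo sapiens) for cytotoxicity, read by resazurin assay, with a stated time of 48 h; on this read-out higher numbers stand for lower toxicity in this test and lower numbers for higher toxicity in this test. In this assay compound 2 gives 33000 nM, the lowest of the two numbers reported. Compound 3 `COc1ccc(Cl)cc1S(=O)(=O)Nc1ccc(-c2nc3ccccc3o2)cc1` gives 75000 nM in this assay. Compound 1 `O=S(=O)(Nc1ccc(-c2nc3ccccc3o2)cc1)c1cccs1` reaches only > 100000 nM in this assay, which is a limit of the assay and not a number; it is the single case sitting at the limit of > 100000 nM in this assay, at which 1 of the 3 values shown sits.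

Compound 4 `Cc1cccc(S(=O)(=O)Nc2ccc3oc(-c4ccccc4)nc3c2)c1` is not yet measured. It differs from compound 2 in one place: 3-methylphenyl in place of 2-hydroxyphenyl on a sulfonyl sulfur.

For the measured compounds named here, the only measured step that touches the same region, an exchange of the group on the sulfonyl sulfur, is an at least 1.3-fold lower number from compound 1 to compound 3 (0.12 log units; that floor lies within the scatter). That step stays within the scatter, though it starts from a limit and the true size could be larger. Going by the values given here, no measured pair shows the loss of a hydroxyl or the gain of a methyl on that arene. Taking the one relevant step as a guide, a change on the sulfonyl sulfur is expected to move the number in this assay little, so compound 4 is estimated to show no step beyond the scatter, with a slight lean toward a higher number, as a 1.2-fold higher number from compound 2 to compound 4 (0.08 log units; within the scatter). Compound 4 is thus expected to give about 40000 nM in this assay, within 15000 nM to 100000 nM.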

Compound 4, half-maximal cytotoxic concentration: 69000 nM
The estimate for compound 4 lay 1.7-fold (0.24 log units) below the measured number; low and high end bracket the measured number.
By their numbers in this assay, from the lowest: compound 2; then compounds 4 and 3 (each within the scatter of the next). At a limit, above all of these: compound 1.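

In this assay, for the compounds shown here, 3-methylphenyl in place of 2-hydroxyphenyl on a sulfonyl sulfur gives a 2.1-fold higher number from compound 2 to compound 4 (0.32 log units; beyond the scatter), the first step at this place that is measured beyond the scatter, since the earlier exchange there, which started from a limit, had only a floor within it. The change at this position can therefore move the number, though modestly, and here it moves toward lower toxicity in this test, with compound 2 remaining the lowest of the numbers shown. Nothing shown gives a reason for this step.

The hydroxyl leaves and the methyl enters in the same step, so the compounds shown leave open how much of the change belongs to each, and whether the same exchange would give a similar step on the core of compound 1. Also open, as far as these compounds go, is how the number would respond to an amine or a carboxylic acid on this arene in place of the hydroxyl, or to a longer chain in place of the methyl.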